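Trading cyclopropyl for ethyl on the amide carbonyl

The source may report more compounds than this note shows. Statements on the series, on what has been measured and on what is new or still open speak of the compounds shown alone.

Compound 1 `Nc1ccc(Cl)cc1C1=NN(C(=O)C2CC2)CC1` was tested in an assay on isolated protein for inhibition of Nitric oxide synthase, inducible (Homo sapiens), with a stated time of 30 min, tested at 1 mM (on this read-out higher numbers stand for more inhibition at the one concentration tested (going by the name of the read-out) and lower numbers for less inhibition), where compound 1 gives 18.9%. Two measured neighbours differ from it only on an aromatic carbon. Compound 2 `Nc1cc(Cl)c(Cl)cc1C1=NN(C(=O)C2CC2)CC1` carries chloro in place of hydrogen there and gives 15.5%, a step of a number 3.4 percentage points lower from compound 1 to compound 2 (within the scatter). Compound 3 `Nc1ccccc1C1=NN(C(=O)C2CC2)CC1` carries hydrogen in place of chloro and gives 14.8%, a step of a number 4.1 percentage points lower from compound 1 to compound 3 (within the scatter). The three numbers thus sit close together, and neither step separates compound 1 from its neighbours beyond the scatter.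

The step now followed leads to compound 4 `CCC(=O)N1CCC(c2cc(Cl)ccc2N)=N1`, which differs from compound 1 in ethyl in place of cyclopropyl on a carbonyl carbon. Within the data shown here, both measured steps concern the aromatic ring, not the group on the carbonyl carbon, so neither bears directly on this change; the record holds no step on the carbonyl substituent at all. What the two measured steps do show is that small changes elsewhere on this shared core left this assay unmoved beyond the scatter. Compound 4 is therefore expected to show a step of a number 1.9 percentage points lower from compound 1 to compound 4 (within the scatter) in this assay, one that stays within the scatter. The estimate for compound 4 is 17%, with a range from 5% to 30%.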

Compound 4, a percentage reported as inhibition, at one concentration (the size of the read-out at that concentration, not a potency): 13.7%
Estimate against measurement, compound 4: 3.3 percentage points above; the range from low to high includes it.
By their numbers in this assay, from the lowest: compounds 4, 3, 2 and 1 (each within the scatter of the next).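

Among these compounds, this is the first step on the carbonyl substituent rather than on the aromatic ring. In this assay, among the compounds shown here, ethyl in place of cyclopropyl on a carbonyl carbon gives a number 5.2 percentage points lower from compound 1 to compound 4 (within the scatter), so this position, like the aromatic carbon, shows no change beyond the scatter for the one swap read here, with cyclopropylcarbonyl giving way to propanoyl and the three-membered ring removed. Nothing at hand explains the size of this step.

All four numbers sit close together at a single concentration, so the compounds shown do not tell whether any group on the carbonyl carbon can separate itself from the others on this read-out. From the compounds shown here alone, whether a longer chain such as butyl, a methyl or an amine on that carbonyl carbon would give a number beyond the scatter of compound 1 remains open, as does whether a change at this position and one on the aromatic carbon would together read differently from either alone.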